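The compounds below may be only part of what the source reports. "The series", "measured", "known", "first", "only" and "open" are said of these compounds alone.

Compound 1 `COc1ccc(S(=O)(=O)NC2=NCCN2C(=S)SN2CCn3c2nsc3=S)cc1`: >= 20000 nM
Compound 2 `CC(=O)Nc1ccc(S(=O)(=O)NC2=NCCN2C(=S)SN2CCn3c2nsc3=S)cc1`: >= 20000 nM

In a functional assay on KYSE-510 cells (Homo sapiens) for antiproliferative activity, read by crystal violet staining, with a stated time of 96 h (a higher number here means a weaker inhibitor of growth, a lower number a stronger inhibitor of growth), compound 1 reaches only a limit of the assay, >= 20000 nM. Compound 2 likewise stops at a limit, >= 20000 nM. Both sit at the limit of >= 20000 nM in this assay, at which 2 of the 2 values shown sit, so the step that the two limits leave unreadable from compound 1 to compound 2 cannot be read, and compound 2 stands at a limit alone. Compound 3 `O=S(=O)(NC1=NCCN1C(=S)SN1CCn2c1nsc2=S)c1ccc(Cl)cc1Cl` is the unmeasured compound; its change from compound 2 is 2,4-dichlorophenyl in place of 4-acetamidophenyl on a sulfonyl sulfur. Among the measured compounds shown here, no measured step bears on this change. For compound 3 a step that the limit leaves unreadable from compound 2 to compound 3 is therefore expected, with little to anchor it. Compound 3 is estimated at 25000 nM, between 5000 nM and 100000 nM, most likely again only a limit.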

Compound 3, concentration for 50% growth inhibition: >= 20000 nM
Compound 3 was reported as a limit; the forecaster's own chance of this, stated with the estimate: 70%; the middle value does not contradict the limit.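

Among the compounds shown here, compound 1, compound 2 and compound 3 all stop at a limit, so no step among them can be read: the limit of >= 20000 nM in this assay, at which 3 of the 3 values shown sit. The compounds shown leave open whether the 4-methoxyphenyl, 4-acetamidophenyl and 2,4-dichlorophenyl groups differ at all in this assay.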